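The compounds below may be only part of what the source reports. "The series", "measured", "known", "first", "only" and "open" are said of these compounds alone.

Measured so far:
compound 1, `CCCCCNc1nc(N)c2nc(O)n(Cc3ccccc3)c2n1`: 0.3 mg/kg
compound 2, `CCc1nc(N)c2nc(O)n(Cc3ccccc3)c2n1`: 3 mg/kg

Both were tested in a functional assay on the whole organism for activation, with Mus musculus as the target; on this read-out higher numbers stand for an effect only at larger amounts of compound and lower numbers for an effect already at smaller amounts. Among the two numbers, compound 1 stands lowest; the one measured step, a 10-fold higher number from compound 1 to compound 2 (1.00 log units; beyond the scatter), shows that exchanging the pentylamino group for ethyl makes the compound act only at a larger dose.

Compound 3, `CCCOc1nc(N)c2nc(O)n(Cc3ccccc3)c2n1`, has not yet been measured. It differs from compound 1 in one place: propoxy in place of pentylamino on an aromatic carbon. This change shares with the measured step the loss of the pentylamino group, but the entering propoxy keeps one hydrogen-bond acceptor and is longer than ethyl. The expectation is therefore a step in the same direction as a 10-fold higher number from compound 1 to compound 2 (1.00 log units; beyond the scatter), yet smaller, and possibly only at the edge of the scatter.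

For compound 3 the estimate is 1 mg/kg, with a range from 0.3 mg/kg to 3 mg/kg. This amounts to an expected step of a 3.3-fold higher number from compound 1 to compound 3 (0.52 log units; beyond the scatter).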

Compound 3, minimum effective dose: 0.3 mg/kg
The estimate for compound 3 lay 3.3-fold (0.52 log units) above the measured number, and the stated range covers the measured number.
By their numbers in this assay, from the lowest: compounds 1 and 3 (each within the scatter of the next); then compound 2.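

In this assay, exchanging pentylamino for propoxy gives no change at the digits printed from compound 1 to compound 3 (within the scatter), so at this position neither the nitrogen with its hydrogen-bond donor nor the pentyl chain is needed to keep the effect at this dose. Propoxy in place of ethyl gives a 10-fold lower number from compound 2 to compound 3 (1.00 log units; beyond the scatter), which shows that the higher number seen with ethyl is tied to that group and does not follow from losing pentylamino as such. Nothing available here explains these results at the level of mechanism.

The compounds shown leave open whether the oxygen or the longer chain of propoxy matters more, since ethyl differs from propoxy in both. A propyl chain joined directly to the ring would separate the two, and a methoxy or pentyloxy group would show how far the chain length at this position can vary.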